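The source may report more compounds than this note shows. Statements on the series, on what has been measured and on what is new or still open speak of the compounds shown alone.

Measured in a physicochemical assay; on this read-out lower numbers stand for stronger inhibition and higher numbers for weaker inhibition:
- compound 1 `CN(C)c1ccc(/C=C/C(=O)/C(CNc2ccccc2)=C(O)/C=C/c2ccc(N(C)C)cc2)cc1` gives 52.1 ug/mL
- compound 2 `CN(C)c1ccc(/C=C/C(=O)/C(CNc2ccc(F)cc2)=C(O)/C=C/c2ccc(N(C)C)cc2)cc1` gives 46.9 ug/mL
- compound 3 `CN(C)c1ccc(/C=C/C(=O)/C(CNc2cccc(C(F)(F)F)c2)=C(O)/C=C/c2ccc(N(C)C)cc2)cc1` gives 74.6 ug/mL

Compound 3 at 74.6 ug/mL lies within the scatter of both compound 1 and compound 2. The step in question leads to compound 4 `COc1ccccc1NC/C(C(=O)/C=C/c1ccc(N(C)C)cc1)=C(O)\C=C\c1ccc(N(C)C)cc1`, with 2-methoxyphenyl in place of 3-(trifluoromethyl)phenyl on an amine nitrogen. The measured steps bearing on this are a 1.1-fold lower number from compound 1 to compound 2 (0.05 log units; within the scatter), a 1.4-fold higher number from compound 1 to compound 3 (0.16 log units; within the scatter) and a 1.6-fold higher number from compound 2 to compound 3 (0.20 log units; within the scatter), all small. Among the compounds with values here, no measured compound carries the 2-methoxyphenyl group, so these steps are the only guide. No step beyond the scatter is expected in this assay. The estimated step is a 1.3-fold lower number from compound 3 to compound 4 (0.11 log units; within the scatter). For compound 4 the expected value is 58 ug/mL, with an estimated range from 33 ug/mL to 100 ug/mL.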

Compound 4, half-maximal inhibitory concentration: 53.9 ug/mL
Compound 4: middle estimate off by 1.1-fold (0.03 log units), on the high side, within the range that was stated.
By their numbers in this assay, from the lowest: compounds 2, 1, 4 and 3 (each within the scatter of the next).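

In this assay the 2-methoxyphenyl group on the amine nitrogen stays within the scatter of all three earlier groups (a 1.4-fold lower number from compound 3 to compound 4 (0.14 log units; within the scatter)) (a 1.1-fold higher number from compound 2 to compound 4 (0.06 log units; within the scatter)) (a 1.0-fold higher number from compound 1 to compound 4 (0.01 log units; within the scatter)). This position has now taken a group with a hydrogen-bond acceptor, and the read-out does not separate it from phenyl, 4-fluorophenyl or 3-(trifluoromethyl)phenyl. No supporting measurement accounts for this flat result.

Going by these compounds, whether any change at this nitrogen moves the number beyond the scatter remains open. A saturated ring such as cyclohexyl, or a phenyl ring carrying a carboxylic acid, would test that.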